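Sulfonyl for Benzyl on the Core Nitrogen, Nothing Yet Readable

The compounds below may be only part of what the source reports. "The series", "measured", "known", "first", "only" and "open" are said of these compounds alone.

Compound 1 `COc1ccc(-c2cc(=O)c3c(OC)cc(OC)cc3n2Cc2ccccc2)cc1` carries a benzyl group on the aromatic nitrogen of the shared core. In a functional assay on HepG2 cells (Homo sapiens) for antiproliferative activity, with a stated time of 72 h (on this read-out higher numbers stand for an effect only at larger amounts of compound and lower numbers for an effect already at smaller amounts), compound 1 gives only a limit of the assay, > 17300 nM, so compound 1 stands among the three values shown with a limit and no number, as do the other two compounds. Compound 2 `COc1ccc(-c2cc(=O)c3c(OC)cc(OC)cc3n2S(=O)(=O)c2ccc([N+](=O)[O-])cc2)cc1` gives in this assay a limit as well, > 29300 nM. Compound 3 `COc1ccc(-c2cc(=O)c3c(OC)cc(OC)cc3n2S(=O)(=O)c2ccc(F)cc2)cc1` likewise gives in this assay a limit, > 65500 nM. Compound 4 `COc1ccc(-c2cc(=O)c3c(OC)cc(OC)cc3n2S(=O)(=O)c2ccc(OC)cc2)cc1` is not yet measured, and it differs from compound 1 by (4-methoxyphenyl)sulfonyl in place of benzyl on an aromatic nitrogen. Going by the values given here, two measured steps bear on this change: a step that the two limits leave unreadable from compound 1 to compound 3 and a step that the two limits leave unreadable from compound 2 to compound 3. Both leave the size of any shift unreadable, as the lines (the limit of > 17300 nM in this assay, at which 1 of the 3 values shown sits), the limit of > 29300 nM in this assay, at which 1 of the 3 values shown sits, and the limit of > 65500 nM in this assay, at which 1 of the 3 values shown sits, show. The expected step is therefore a step that the limit leaves unreadable from compound 1 to compound 4, with no shift beyond the scatter that could be read. For compound 4 the estimate is 50000 nM, within a range from 15000 nM to 200000 nM, most probably reported again as a limit only.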

Compound 4, half-maximal effective concentration: > 82700 nM
Compound 4 gave a limit, no number (the forecaster's own chance of this, stated with the estimate: 85%); middle value at least 1.6-fold (0.21 log units) from the limit.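

In this assay compound 4 gives only a limit, > 82700 nM. Going by these compounds alone, with all four values being limits, no step from compound 1, compound 2 or compound 3 to compound 4 can be read. The compounds shown leave open how any of these groups on the aromatic nitrogen compare in size of effect.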